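Cytotoxicity limits across three nitroimidazooxazine biaryl ethers

This account rests on a few compounds, and the source may have more. Where it says the series, first, only, none or still open, it means among the compounds named here.

Compound 1 `O=[N+]([O-])c1cn2c(n1)OC[C@@H](OCc1ccc(-c3ccc(OC(F)(F)F)cc3)cc1C(F)(F)F)C2`: in an ADME assay on Vero cells (Chlorocebus sabaeus) for cytotoxicity, with a stated time of 72 h (on this read-out higher numbers stand for weaker inhibition and lower numbers for stronger inhibition), compound 1 gives > 128000 nM, which is a limit of the assay and not a number.
Compound 2 `O=[N+]([O-])c1cn2c(n1)OC[C@@H](OCc1ccc(-c3ccc(OC(F)(F)F)cc3)cc1OC(F)(F)F)C2`: in this assay compound 2 gives > 128000 nM, again a limit of the assay.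
Compound 3 `O=[N+]([O-])c1cn2c(n1)OCC(COc1ccc(-c3ccc(OC(F)(F)F)cc3)cn1)C2`: in this assay compound 3 gives > 128000 nM, also a limit of the assay.

All three measured compounds sit at the same limit, (the limit of > 128000 nM in this assay, at which 3 of the 3 values shown sit), so none of them can be ranked against another. Compound 2 and compound 1 differ by one change, (trifluoromethyl in place of trifluoromethoxy on an aromatic carbon), and the step that the two limits leave unreadable from compound 2 to compound 1 cannot be read because both values are limits. Compound 3 carries a different core from compound 2; the difference between the two cores is not broken down here.

Compound 4 `O=[N+]([O-])c1cn2c(n1)OCC(COc1ccc(-c3ccc(C(F)(F)F)cc3)cn1)C2` is not yet measured. It stands to compound 3 as compound 1 stands to compound 2: trifluoromethyl in place of trifluoromethoxy on an aromatic carbon. The two changes are of the same kind rather than the same, since in compound 1 the new group sits ortho to a large group and meta to a 4-(trifluoromethoxy)phenyl group, whereas in compound 4 it sits para to a large group.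

Compound 4 is expected to show a step of about a number no higher from compound 3 to compound 4 (the limit leaves the size open), which rests on compound 3 giving > 128000 nM and on compound 1 and compound 2 both sitting at the limit of > 128000 nM in this assay, at which 3 of the 3 values shown sit, after the same kind of change. Compound 4 is therefore estimated to fall at 128000 nM, with a range of 64000 nM to 256000 nM, most likely reported only as a limit.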

Compound 4, half-maximal inhibitory concentration: > 128000 nM
Compound 4 ended at the assay's limit (the forecaster's own chance of this, stated with the estimate: 85%); the middle value sits exactly at the limit.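

In this assay compound 4 gives > 128000 nM and this is a limit of the assay, not a number. Among the compounds shown here, compound 3 also sits at a limit, so no step from compound 3 to compound 4 can be read: the limit of > 128000 nM in this assay, at which 4 of the 4 values shown sit. The compounds shown leave open what actual value any of them has, and whether trifluoromethyl in place of trifluoromethoxy changes that value at all.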